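The compounds below may be only part of what the source reports. "The series", "measured", "known", "first", "only" and "open" are said of these compounds alone.

Measured compounds:

Compound 1 `COc1ccc(-c2nn(-c3ccccc3)cc2/C=C/C(=O)c2ccc(OCc3ccccc3)c3c2OC(C)(C)C3)cc1`: in a functional assay on HT-29 cells (Homo sapiens) for antiproliferative activity, read by MTT assay, with a stated time of 48 h (a lower number here means a stronger inhibitor, a higher number a weaker inhibitor), compound 1 gives > 100000 nM, a limit of the assay.

Compound 2 `CC1(C)Cc2c(ccc(C(=O)/C=C/c3ccc(Cl)cc3Cl)c2OCc2ccccc2)O1`: in this assay compound 2 gives > 100000 nM, a limit of the assay.

Compound 3 `CC1(C)Cc2c(ccc(C(=O)/C=C/c3cn(-c4ccccc4)nc3-c3ccccc3)c2OCc2ccccc2)O1`: in this assay compound 3 gives > 100000 nM, a limit of the assay.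

Compound 2 therefore stands where every measured compound stands: only a limit is known for it, and the two other values are limits as well (the limit of > 100000 nM in this assay, at which 3 of the 3 values shown sit). Among the measured compounds shown here, no step between measured compounds can be read, and no compound can be called stronger or weaker than another.

Compound 4 `CC1(C)Cc2c(ccc(C(=O)/C=C/c3ccccc3)c2OCc2ccccc2)O1` differs from compound 2 in one place: phenyl in place of 2,4-dichlorophenyl on a double-bonded chain carbon bound to a double-bonded chain carbon. With three limits and no numbered value, there is no basis for expecting a step in either direction beyond the scatter. Compound 4 is therefore expected to return another limit, with the expected step of a number no higher from compound 2 to compound 4 (the limit leaves the size open) amounting to none, and its estimate is 100000 nM, within 30000 nM to 300000 nM.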

Compound 4, half-maximal inhibitory concentration: > 100000 nM
Compound 4 was reported as a limit (the forecaster's own chance of this, stated with the estimate: 85%); the middle value lies on the limit itself.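

In this assay compound 4 gives > 100000 nM, a limit of the assay. Among the compounds shown here, compound 2 also sits at a limit, so no step between compound 2 and compound 4 can be read. The compounds shown leave open whether any of them differs in strength from another.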